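The source may report more compounds than this note shows. Statements on the series, on what has been measured and on what is new or still open speak of the compounds shown alone.

Going by the values given here, in a functional assay on HCT-116 cells (Homo sapiens) for cytotoxicity, read by MTT assay, with a stated time of 72 h (a higher number here means a weaker inhibitor, a lower number a stronger inhibitor), compound 1 `Nc1ccccc1NC(=O)c1ccc(NC(=S)NCc2ccccc2F)cc1` gives 6300 nM, the only actual number available for the series. Compound 2 `Nc1ccccc1NC(=O)c1ccc(Cn2cc(-c3ccc(NC(=O)NCc4cccnc4)cc3)nn2)cc1` is reported as > 100000 nM, which is a limit of the assay and not a number. Compound 3 `Cc1ccc(CNC(=S)Nc2ccc(C(=O)Nc3ccccc3N)cc2)cn1` keeps the core of compound 1 but carries 6-methylpyridin-3-yl in place of 2-fluorophenyl on a saturated chain carbon bound to an amide-type nitrogen. Among the compounds with values here, no measured pair of compounds shows what such a swap does, so the expectation rests on the value of compound 1 at 6300 nM and on the equal size of the entering and leaving groups. A small loss of strength in this assay is expected, little beyond the usual scatter, with the estimated change being a 1.3-fold higher number from compound 1 to compound 3 (0.10 log units; within the scatter). For compound 3 the estimated value is 8000 nM, with an expected range from 2500 nM to 25000 nM.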

Compound 3, half-maximal inhibitory concentration: 11000 nM
For compound 3 the middle estimate is 1.4-fold (0.14 log units) below the measured one; low and high end bracket the measured number.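

Set against compound 1, compound 3 gives the first measured step at this position: in this assay, 6-methylpyridin-3-yl in place of 2-fluorophenyl on a saturated chain carbon bound to an amide-type nitrogen gives a 1.7-fold higher number from compound 1 to compound 3 (0.24 log units; within the scatter), so no change can be claimed. The position thus holds a six-membered aromatic ring with a hetero atom and a hydrogen-bond acceptor, in place of a ring of carbon only, with activity that cannot be told apart from that of compound 1. Nothing in the available evidence bears on why this step stays so small.

The compounds shown leave open whether the ring nitrogen and the methyl each matter on their own. Going by these compounds, how an amine or a carboxylic acid on this ring, or a longer chain carrying it, would read also remains open.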